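The source may report more compounds than this note shows. Statements on the series, on what has been measured and on what is new or still open speak of the compounds shown alone.

In an ADME assay on L02 cells (Homo sapiens) for antiproliferative activity, read by MTT assay, with a stated time of 48 h (on this read-out higher numbers stand for weaker inhibition and lower numbers for stronger inhibition), every value shown so far is a limit rather than a number. Compound 3 `Cc1ccccc1-n1nncc1CN1C(=O)C2(C(C#N)=C(N)Oc3c(N)cc4nc5ccccc5nc4c32)c2ccccc21` reaches only a limit in this assay, > 50000 nM. Compound 1 `N#CC1=C(N)Oc2c(c3nc4ccccc4nc3c3ccccc23)C12C(=O)N(Cc1cnnn1-c1ccc(Cl)cc1)c1ccccc12` likewise gives only a limit in this assay, > 50000 nM. Compound 2 `N#CC1=C(N)Oc2c(c3nc4ccccc4nc3c3ccccc23)C12C(=O)N(Cc1cnnn1-c1ccc(Cl)c(Cl)c1)c1ccccc12` gives a limit in this assay as well, > 50000 nM. Within the data shown here, the single measured step, chloro in place of hydrogen on an aromatic carbon, reads a step that the two limits leave unreadable from compound 1 to compound 2, so its size cannot be told. All three values sit at the limit of > 50000 nM in this assay, at which 3 of the 3 values shown sit, and compound 3 therefore stands exactly where the other two measured compounds stand, with nothing to rank it against.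

Compound 4 `N#CC1=C(N)Oc2c(N)cc3nc4ccccc4nc3c2C12C(=O)N(Cc1cnnn1-c1ccc(F)cc1)c1ccccc12` differs from compound 3 by 4-fluorophenyl in place of 2-methylphenyl on an aromatic nitrogen. No measured step touches this part of the molecule, and the one step that exists is unreadable, so no size or direction can be drawn from the shown numbers. The expected step is a step that the limit leaves unreadable from compound 3 to compound 4, most probably ending in another limit. For compound 4 in this assay the estimate is 60000 nM, within a range from 30000 nM to 200000 nM.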

Compound 4, half-maximal inhibitory concentration: > 50000 nM
Compound 4 was reported as a limit; the forecaster's own chance of this, stated with the estimate: 85%; the middle value is on the limit's open side.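

Compound 3 and compound 4 both end in limits rather than numbers, so no step can be read for 4-fluorophenyl in place of 2-methylphenyl. Every value shown now sits at one limit: the limit of > 50000 nM in this assay, at which 4 of the 4 values shown sit. The compounds shown leave open whether any change to the shared core would give a number rather than a limit in this assay.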